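Hydroxy for chloro on the aryl ring of compound 1

The source may hold more compounds than are shown below. What is called first, only, known or untested is meant among the compounds shown, and "the series" means these compounds.

Measured compounds:
compound 1, `O=[N+]([O-])c1cn2c(n1)OC[C@@H](NCc1ccc(OC(F)(F)F)c(Cl)c1)C2`, 0.223 h
compound 2, `CCCN(Cc1ccc(OC(F)(F)F)cc1)[C@@H]1COc2nc([N+](=O)[O-])cn2C1`, 0.0567 h
compound 3, `O=[N+]([O-])c1cn2c(n1)OC[C@@H](NCc1ccc(OC(F)(F)F)cc1Oc1ccccc1)C2`, 0.107 h

In an in vitro ADME assay on the whole organism (microsomes, liver, Mus musculus) for metabolic stability, read by LC-MS, with a stated time of 24 h, at a dose of 5 mg/kg by the intravenous route (on this read-out lower numbers stand for a shorter-lived compound and higher numbers for a longer-lived compound), compound 1 stands highest of the three numbers; compound 3 gives 0.107 h, a lower number beyond the scatter, and compound 2 gives 0.0567 h, lower still and also beyond the scatter. Compound 4, `O=[N+]([O-])c1cn2c(n1)OC[C@@H](NCc1ccc(OC(F)(F)F)c(O)c1)C2`, differs from compound 1 in one place: hydroxy in place of chloro on an aromatic carbon. Going by the values given here, no measured pair shows this change, so its size is unknown. Compound 4 is expected to give a somewhat lower number, a step beyond the scatter of a 2.0-fold lower number from compound 1 to compound 4 (0.31 log units; beyond the scatter). The estimate for compound 4 is 0.11 h, within 0.045 h to 0.28 h.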

Compound 4, half-life: 0.373 h
The estimate for compound 4 lay 3.4-fold (0.53 log units) below the measured number; measured number above the stated range.
By their numbers in this assay, from the lowest: compounds 2 and 3 (each within the scatter of the next); then compounds 1 and 4 (each within the scatter of the next).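

In this assay, hydroxy in place of chloro on this aromatic carbon, ortho to a trifluoromethoxy group, gives a 1.7-fold higher number from compound 1 to compound 4 (0.22 log units; within the scatter). Going by these compounds alone, this is the first single-place comparison, and it shows that the exchange, which brings in a hydrogen-bond donor and acceptor, leaves the half-life indistinguishable from that of the chloro compound. Nothing available bears on the reason for this result. On these data alone, whether a methoxy group, an amine or a carboxylic acid on the same carbon would also read alike remains open.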